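Aryl exchange and liver clearance across two cores

This account rests on a few compounds, and the source may have more. Where it says the series, first, only, none or still open, it means among the compounds named here.

Compound 1 `O=S(=O)(c1cc(Cl)cc(Cl)c1)c1cnc2cc(F)ccc2c1-c1ccccc1F` gives 0.93 mL/min in an ADME assay on microsomes from liver (Homo sapiens) for metabolic stability, tested at 2.5 uM; on this read-out higher numbers stand for fast clearance and lower numbers for slow clearance. Compound 2 `O=S(=O)(c1cc(Cl)cc(Cl)c1)c1cnc2cc(F)ccc2c1-c1ccc(Cl)cc1` carries 4-chlorophenyl in place of 2-fluorophenyl on an aromatic carbon and in this assay gives 0.13 mL/min, a step of a 7.2-fold lower number from compound 1 to compound 2 (0.85 log units; beyond the scatter). Compound 3 `O=S(=O)(c1cccc(F)c1)c1cnc2c(F)cccc2c1-c1ccccc1F` rests on a core whose difference from the core of compound 1 is not broken down here; in this assay compound 3 gives 0.21 mL/min, which sits within the scatter of the number for compound 2, while the number for compound 1 stands higher, beyond the scatter. Compound 4 `O=S(=O)(c1cccc(F)c1)c1cnc2c(F)cccc2c1-c1ccc(Cl)cc1` is not yet measured and carries 4-chlorophenyl in place of 2-fluorophenyl on an aromatic carbon, the same change as from compound 1 to compound 2, at a place described in the same words. Within the data shown here, the step expected in this assay is a 4.2-fold lower number from compound 3 to compound 4 (0.62 log units; beyond the scatter), because the one earlier instance of this change measured as a 7.2-fold lower number from compound 1 to compound 2 (0.85 log units; beyond the scatter); a single instance gives no check on whether the core alters the size. Compound 4 is therefore estimated at 0.05 mL/min, with a range from 0.015 mL/min to 0.17 mL/min.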

Compound 4, intrinsic clearance in a liver preparation (reported as CLH), per the amount of preparation that the assay uses: 0.62 mL/min
The estimate for compound 4 lay 12-fold (1.09 log units) below the measured number; measured number above the stated range.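

In this assay, the exchange of 2-fluorophenyl for 4-chlorophenyl does not carry over from one core to the other, and its direction reverses: the same change on two cores in this assay, a 7.2-fold lower number (0.85 log units; beyond the scatter) from compound 1 to compound 2 and a 3.0-fold higher number (0.47 log units; beyond the scatter) from compound 3 to compound 4, 21-fold (1.32 log units) apart, beyond the scatter of two such steps

Read alone, the new result is a 3.0-fold higher number from compound 3 to compound 4 (0.47 log units; beyond the scatter), so the step measured on the core of compound 1 cannot be used as a forecast on the core of compound 3. The two pairs show that the outcome of the exchange depends on its surroundings, but they differ in more than one place and do not show which difference is responsible.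

Going by these compounds, whether a third core would follow either pair stays open. Also open, on these data alone, is how an amine or a carboxylic acid in place of the 4-chlorophenyl would behave in this assay.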